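A few compounds are considered here, and "the series" means these few. Any claim that something is new, unique, unknown or untested is made for them only; others in the source may bear on it.

Compound 1, with the structure `COc1cc(Cl)cc(-c2nn(-c3cccc(NC(=O)c4ccc(Cl)c(Cl)c4)c3)cc2-c2ccncc2)c1`, was tested in a functional assay on SF-268 cells (Homo sapiens) for inhibition, read by sulforhodamine B assay, with a stated time of 48 h, tested at 10 uM (on this read-out lower numbers stand for a stronger effect and higher numbers for a weaker effect at the one concentration tested), where compound 1 gives 82.4%. Compound 2, with the structure `COc1cc(Cl)cc(-c2nn(-c3cccc(NC(=O)Nc4ccc(Cl)c(C(F)(F)F)c4)c3)cc2-c2ccncc2)c1`, gives 22.9% in this assay. For the measured compounds named here, the one measured step, a number 59.5 percentage points lower from compound 1 to compound 2 (beyond the scatter), is large and well beyond the usual scatter. On the two numbers shown, compound 2 stands lowest, with compound 1 the only neighbour, a good deal higher.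

Compound 3, with the structure `COc1cc(Cl)cc(-c2nn(-c3cccc(NC(=O)Nc4ccc(Cl)c(Cl)c4)c3)cc2-c2ccncc2)c1`, has not yet been measured in this assay. It differs from compound 2 in one place: chloro in place of trifluoromethyl on an aromatic carbon. Going by the values given here, no measured step isolates this exchange; the step from compound 1 to compound 2 alters more than one feature at once, so it bears on compound 3 only loosely. For compound 3 a step within the scatter is therefore expected, a number 2.1 percentage points higher from compound 2 to compound 3 (within the scatter), and compound 3 is estimated at 25%, within a range from 8% to 50%.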

Compound 3, a percentage reported as activity, at one concentration (the size of the read-out at that concentration, not a potency): 25.3%
Compound 3: middle estimate off by 0.3 percentage points, on the low side; the range from low to high includes it.
By their numbers in this assay, from the lowest: compounds 2 and 3 (each within the scatter of the next); then compound 1.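

In this assay, putting chloro in place of trifluoromethyl on this aromatic carbon gives a number 2.4 percentage points higher from compound 2 to compound 3 (within the scatter), so the read-out does not separate these two groups at this position. With the 3,4-dichlorophenyl group now held the same, adding the amino group on the carbonyl carbon gives a number 57.1 percentage points lower from compound 1 to compound 3 (beyond the scatter); this single change carries a large step by itself, which the earlier pair could not show because two features changed there at once. Nothing available explains either result.

The compounds shown leave open how a methoxy group or a nitrile would read on this same aromatic carbon, since only trifluoromethyl and chloro can be compared there. They also leave open whether an oxygen or a methylene group in place of the amino group would keep the large step.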